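Series notes: replacing methoxy with hydrogen on compound 2

This account rests on a few compounds, and the source may have more. Where it says the series, first, only, none or still open, it means among the compounds named here.

Two compounds of this series have numbers in a functional assay on the whole organism (strain Swiss albino) for inhibition, with Mus musculus as the target, with a stated time of 4 h; a lower number here means that less compound is needed, a higher number that more compound is needed for the effect. Compound 1 `O=[N+]([O-])c1ccc(-c2csc(Nc3n[nH]c(=S)n3-c3ccccc3)n2)cc1` gives 300 mg/kg in this assay. Compound 2 `COc1ccc(-n2c(Nc3nc(-c4ccc(Cl)cc4)cs3)n[nH]c2=S)cc1` gives 100 mg/kg in this assay, the lowest of the two numbers; the nearest is compound 1, with a higher number, a gap beyond the scatter. For the measured compounds named here, compounds 1 and 2 differ in more than one place, so no single step between them is given.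

Compound 3 `S=c1[nH]nc(Nc2nc(-c3ccc(Cl)cc3)cs2)n1-c1ccccc1` has not been measured in this assay. Compared with compound 2 it carries the change (hydrogen in place of methoxy on an aromatic carbon). Cut one bond further out, the change reads 4-methoxyphenyl to phenyl.

Going by the values given here, no measured pair in this set isolates this change, so the size of its step is not known from the data. Among the compounds with values here, a step from compound 2 to compound 3 that stays within the scatter, or a modest rise in the number, is expected: compound 2 gives 100 mg/kg, and the only other compound, compound 1 with its 300 mg/kg, differs in two places and so sets no direction for this change alone. The expected step is a 1.5-fold higher number from compound 2 to compound 3 (0.18 log units; within the scatter). Compound 3 is estimated at 150 mg/kg, with a range of 70 mg/kg to 300 mg/kg.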

Compound 3, minimum effective dose: 300 mg/kg
Beside the measured number, compound 3's estimate is 2.0-fold (0.30 log units) below it; the measured number falls inside the stated range.
By their numbers in this assay, from the lowest: compound 2; then compounds 1 and 3 (each within the scatter of the next).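

Hydrogen in place of methoxy, para to a large group, gives in this assay a 3.0-fold higher number from compound 2 to compound 3 (0.48 log units; beyond the scatter) and so provides the first reading of this change alone, with the 4-methoxyphenyl compound needing less compound for the effect than its phenyl counterpart. With phenyl held in place, chloro in place of nitro on an aromatic carbon shows no change at the digits printed from compound 1 to compound 3 (within the scatter) and so separates the two groups not at all in this assay within this pair. Nothing on hand gives a reason for either step.

The compounds shown leave open whether the gain belongs to methoxy specifically or would also appear with another group at the same place, such as hydroxy, ethoxy, fluoro or an amine. They also leave open whether the methoxy step would be of similar size with nitro in place of chloro, since methoxy appears here only together with chloro, and whether a longer alkoxy chain would take the number further in either direction.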